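Trading a phenoxy for a methoxy on a thiourea core

The compounds below may be only part of what the source reports. "The series", "measured", "known", "first", "only" and "open" are said of these compounds alone.

Of the compounds shown here, three sharing one core have been measured in a functional assay on SK-MEL-5 cells (Homo sapiens) for cytotoxicity, read by sulforhodamine B assay, with a stated time of 48 h; a lower number here means a stronger inhibitor of growth, a higher number a weaker inhibitor of growth. Compound 1 `CC1=C(C(=O)Nc2ccc(Cl)c(Cl)c2)C(c2cccc(Oc3ccccc3)c2)NC(=S)N1` gives 7940 nM. Compound 2 `CC1=C(C(=O)Nc2ccc(F)c(Cl)c2)C(c2ccccc2Cl)NC(=S)N1` gives 12300 nM, and compound 3 `CC1=C(C(=O)Nc2ccc(F)c(Cl)c2)C(c2cccc(Cl)c2)NC(=S)N1` gives 8320 nM. The numbers of all three sit close together, with every gap within the scatter, so compound 1 cannot be set apart from the other two on these results alone.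

Among the compounds with values here, the one step measured so far, a 1.5-fold lower number from compound 2 to compound 3 (0.17 log units; within the scatter), moves a chlorine around a ring attached to the saturated ring carbon and stays within the scatter.

Compound 4 `COc1cccc(C2NC(=S)NC(C)=C2C(=O)Nc2ccc(Cl)c(Cl)c2)c1` differs from compound 1 in another place entirely: methyl in place of phenyl on an oxygen on an aromatic ring. Within the data shown here, no measured step touches the group on that oxygen, so the only guidance is that the one change tried elsewhere on this core barely moved the number. On that basis the step from compound 1 to compound 4 is expected to be small, a 1.1-fold higher number from compound 1 to compound 4 (0.05 log units; within the scatter), with no clear direction. Compound 4 is therefore estimated at 9000 nM, within a range from 4000 nM to 20000 nM.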

Compound 4, concentration for 50% growth inhibition: 9550 nM
The estimate for compound 4 lay 1.1-fold (0.03 log units) below the measured number; the measured number falls inside the stated range.
By their numbers in this assay, from the lowest: compounds 1, 3, 4 and 2 (each within the scatter of the next).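

Within the data shown here, this is the first measured change to the group on the oxygen, and replacing phenyl with methyl gives a 1.2-fold higher number from compound 1 to compound 4 (0.08 log units; within the scatter) in this assay. Phenoxy and methoxy therefore cannot be told apart here, so on this core the phenyl, with its six heavy atoms and aromatic ring, is not required for growth inhibition at this level. Nothing available explains why the exchange makes so little difference.

As far as these compounds go, it remains open whether the number would hold with a longer chain such as butyl on that oxygen, with a chain ending in an amine or a carboxylic acid, or with a plain hydroxyl at that place. Also open, from the compounds shown here alone, is whether the phenoxy-to-methoxy exchange would behave the same way with the different amide ring carried by compound 2 and compound 3.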